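Swapping an isopentyl chain for an oxime ether on a shared core

This account rests on a few compounds, and the source may have more. Where it says the series, first, only, none or still open, it means among the compounds named here.

Compound 2 `CC(C)CCOc1ccc(C(=O)Nc2cccc(C(=O)O)c2)cc1` gives 215 nM in an assay on isolated protein for agonist activity at Bile acid receptor (Homo sapiens), read by TR-FRET, with a stated time of 3 h, in the absence of a further agent (a higher number here means that more compound is needed for the effect, a lower number that less compound is needed), the second highest of three numbers. Compound 1 `O=C(O)c1cccc(NC(=O)c2ccc(Oc3ccccc3)cc2)c1` gives 97 nM, and compound 3 `Cc1ccccc1-c1cccc(COc2ccc(C(=O)Nc3cccc(C(=O)O)c3)cc2)c1` gives 1030 nM. Among the measured compounds shown here, the only measured step, a 2.2-fold higher number from compound 1 to compound 2 (0.35 log units; beyond the scatter), shows a modest move. Compound 4 `CO/N=C(/COc1ccc(C(=O)Nc2cccc(C(=O)O)c2)cc1)c1ccccc1` differs from compound 2 by a group of 10 heavy atoms (8 carbon, 1 nitrogen, 1 oxygen; one six-membered aromatic ring of carbon only) in place of a group of 4 heavy atoms (4 carbon; no ring), on a saturated chain carbon bound to an oxygen on an aromatic ring. For the measured compounds named here, no measured pair copies this change; compound 1, which also carries an aromatic ring on the ether oxygen, sits lower than compound 2, while compound 3, with a larger aromatic group there, sits far higher. Weighing both, compound 4 is expected to land near compound 2, with a step of a 1.4-fold higher number from compound 2 to compound 4 (0.14 log units; within the scatter), estimated at 300 nM within a range of 100 nM to 900 nM.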

Compound 4, half-maximal effective concentration: > 10000 nM
Compound 4 gave a limit, no number; the forecaster's own chance of this, stated with the estimate: 5%; middle value at least 33-fold (1.52 log units) from the limit.
By their numbers in this assay, from the lowest: compound 1; then compound 2; then compound 3. At a limit, above all of these: compound 4.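

Among the compounds shown here, the group on the ether oxygen can matter far more than the earlier compounds showed: in this assay the oxime ether gives an at least 46-fold higher number from compound 2 to compound 4 (1.66 log units; beyond the scatter), against the modest 2.2-fold higher number from compound 1 to compound 2 (0.35 log units; beyond the scatter). Compound 4 gives a limit of the assay, not a number: the limit of > 10000 nM in this assay, at which 1 of the 4 values shown sits.

On these data alone, it remains open whether the aromatic ring or the oxime ether accounts for this loss, as compound 4 brings in both together. A phenethyl group, which has the ring without the oxime ether, and a chain carrying the methyl oxime ether without the ring would separate the two.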